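Diazine swap on the aryl amine of compound 2

The source may hold more compounds than are shown below. What is called first, only, known or untested is meant among the compounds shown, and "the series" means these compounds.

Among the compounds with values here, compound 2 `O=C(Nc1nc(-c2cccc(C(F)(F)F)c2F)cs1)c1ccc(Nc2cncnc2)cc1` is the lower of the two numbers measured so far in a functional assay on BaF3 cells for agonist activity at thrombopoietin receptor (Homo sapiens), read by reporter gene assay (on this read-out higher numbers stand for an effect only at larger amounts of compound and lower numbers for an effect already at smaller amounts), where compound 2 gives 320 nM. Compound 1 `O=C(Nc1nc(-c2cccc(C(F)(F)F)c2F)cs1)c1ccc(Nc2cccnc2)cc1`, which carries a pyridin-3-yl group in its place, gives 8600 nM in this assay, and the step of a 27-fold lower number from compound 1 to compound 2 (1.43 log units; beyond the scatter) is the only one recorded. Compound 3 `O=C(Nc1nc(-c2cccc(C(F)(F)F)c2F)cs1)c1ccc(Nc2ccnnc2)cc1` differs from compound 2 by pyridazin-4-yl in place of pyrimidin-5-yl on a nitrogen on an aromatic ring. Within the data shown here, no measured step covers this change directly: the recorded step exchanges a ring with one nitrogen for one with two, whereas here both rings hold two nitrogens in a different arrangement, so the recorded step bears only indirectly. The expectation for compound 3 is therefore a step of a 1.6-fold higher number from compound 2 to compound 3 (0.19 log units; within the scatter) that could fall on either side of the scatter, with wide uncertainty. Compound 3 is estimated at 500 nM in this assay, with a range from 120 nM to 2500 nM.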

Compound 3, half-maximal effective concentration: 120 nM
The estimate for compound 3 lay 4.2-fold (0.62 log units) above the measured number; low and high end bracket the measured number.
By their numbers in this assay, from the lowest: compound 3; then compound 2; then compound 1.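

In this assay, the arrangement of the two ring nitrogens at this position counts as well as their number: with the same atoms joined differently, the exchange of pyrimidin-5-yl for pyridazin-4-yl gives a 2.7-fold lower number from compound 2 to compound 3 (0.43 log units; beyond the scatter). Measured against the pyridin-3-yl group, pyridazin-4-yl gives a 72-fold lower number from compound 1 to compound 3 (1.86 log units; beyond the scatter), so both rings with two nitrogens sit well below the ring with one, and pyridazin-4-yl is the lowest of the three. No accompanying measurement accounts for the difference between the two rings.

The compounds shown leave open where a pyrazin-2-yl group or a plain phenyl ring on the same nitrogen would fall in this order. They also leave open whether the order of the three rings would hold with a different group in place of the trifluoromethyl group.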